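A Second Methyl Placement on an Inactive Core

This account rests on a few compounds, and the source may have more. Where it says the series, first, only, none or still open, it means among the compounds named here.

Compound 1 `Brc1ccc(-c2cc3ccccc3o2)cc1` is the reference point of this small set. In an assay on cells for inhibition of Amine oxidase [flavin-containing] A (Homo sapiens), read by fluorescence and Amplex Red, with a stated time of 15 min (on this read-out lower numbers stand for stronger inhibition and higher numbers for weaker inhibition), compound 1 gives > 100000 nM, which is a limit of the assay and not a number, so only a limit is known for where compound 1 stands. Compound 2 `Cc1cccc2cc(-c3ccc(Br)cc3)oc12` carries a methyl on an aromatic carbon of the shared core, and in this assay compound 2 gives 100000 nM. Compound 3 `Brc1cccc(-c2cc3ccccc3o2)c1` is the third measured compound; in this assay compound 3 gives 100000 nM. For the measured compounds named here, the only measured step, a number no higher from compound 1 to compound 2 (the limit leaves the size open), is a methyl in place of hydrogen on an aromatic carbon; its size cannot be read because the limit of > 100000 nM in this assay, at which 1 of the 3 values shown sits, is where compound 1 sits, and the value of compound 2 stays at the top of the measured range.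

Compound 4 `Cc1ccc2oc(-c3ccc(Br)cc3)cc2c1` has not yet been measured. It differs from compound 1 by methyl in place of hydrogen on an aromatic carbon. The step from compound 1 to compound 2 bears on it directly, and that step gave no sign of gained inhibition. Compound 4 is therefore expected to show a number no higher from compound 1 to compound 4 (the limit leaves the size open), that is, no step beyond the scatter. The estimate for compound 4 in this assay is 100000 nM, with a range from 30000 nM to 300000 nM, and a high chance that only a limit is reported.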

Compound 4, half-maximal inhibitory concentration: > 100000 nM
Compound 4: only a limit was reported; the forecaster's own chance of this, stated with the estimate: 60%; the middle value sits exactly at the limit.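

In this assay compound 4 gives > 100000 nM, which is a limit of the assay and not a number. For the compounds shown here, compound 1 also stands only at a limit, so no step between compound 1 and compound 4 can be read. The compounds shown leave open whether this methyl in place of hydrogen changes inhibition at all.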